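Adding a Chloro Group to a Methylpiperidine Analogue

The source may report more compounds than this note shows. Statements on the series, on what has been measured and on what is new or still open speak of the compounds shown alone.

Two related compounds have been tested in a functional assay on NCI-H460 cells (Homo sapiens) for cytotoxicity, read by MTT assay, with a stated time of 72 h; on this read-out higher numbers stand for weaker inhibition and lower numbers for stronger inhibition. Compound 1 `COc1cc2c(Oc3ccc(NC(=O)c4cn(-c5ccccc5Cl)nn4)cc3F)ccnc2cc1OCCCN1CCCC1` gives 190 nM. Compound 2 `COc1cc2c(Oc3ccc(NC(=O)c4cn(-c5ccccc5)nn4)cc3F)ccnc2cc1OCCCN1CCC(C)CC1` gives 210 nM, the higher of the two numbers, though the gap to compound 1 lies within the usual scatter, so the pair show no real separation. Compound 3 `COc1cc2c(Oc3ccc(NC(=O)c4cn(-c5ccccc5Cl)nn4)cc3F)ccnc2cc1OCCCN1CCC(C)CC1` is now to be measured. It differs from compound 2 by chloro in place of hydrogen on an aromatic carbon. Because compound 1, which carries the same chloro group, gives 190 nM close to compound 2, the change from compound 2 to compound 3 is expected to bring no step beyond the scatter: a 1.1-fold lower number from compound 2 to compound 3 (0.02 log units; within the scatter). Compound 3 is therefore estimated at 200 nM, ranging from 100 nM to 400 nM.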

Compound 3, half-maximal inhibitory concentration: 230 nM
Compound 3: the middle estimate sits 1.2-fold (0.06 log units) below what was measured, and the stated range covers the measured number.
By their numbers in this assay, from the lowest: compounds 1, 2 and 3 (each within the scatter of the next).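

In this assay, phenyl to 2-chlorophenyl gives a 1.1-fold higher number from compound 2 to compound 3 (0.04 log units; within the scatter) and so, in this pair, chloro and hydrogen on this aromatic carbon, ortho to a large group, do not separate. With the 2-chlorophenyl held fixed, 4-methylpiperidin-1-yl in place of pyrrolidin-1-yl gives a 1.2-fold higher number from compound 1 to compound 3 (0.08 log units; within the scatter) and so this second single change shows no separation either. Nothing available explains either result.

From the compounds shown here alone, whether a methoxy group, a carboxylic acid or an amine at this carbon would stand apart from hydrogen remains open. So does the effect of a morpholine ring at the end of the chain.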